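Dropping the Trifluoromethyl from an Inactive Benzamide

This account rests on a few compounds, and the source may have more. Where it says the series, first, only, none or still open, it means among the compounds named here.

Compound 1 `O=C(Nc1ccc(Cl)c(-c2nnc3c(Cl)cccn23)c1)c1ccc(C(F)(F)F)cc1Cl` is one of three amides sharing the same core. In a functional assay on U-251 cells (Homo sapiens) for antiproliferative activity, read by MTT assay, with a stated time of 72 h (a higher number here means a weaker inhibitor, a lower number a stronger inhibitor), compound 1 reaches only a limit of the assay, > 100000 nM. Compound 2 `Cc1nc(C(=O)Nc2ccc(Cl)c(-c3nnc4c(Cl)cccn34)c2)cs1` gives 74300 nM in this assay. Compound 3 `CS(=O)(=O)c1ccc(C(=O)Nc2ccc(Cl)c(-c3nnc4c(Cl)cccn34)c2)cc1` likewise shows only a limit, > 100000 nM. For the measured compounds named here, the sole measured step, an at least 1.3-fold higher number from compound 2 to compound 3 (0.12 log units; that floor lies within the scatter), concerns a change on the carbonyl carbon and not the change considered here; moreover (the limit of > 100000 nM in this assay, at which 2 of the 3 values shown sit), so little can be read from it.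

Compound 4 `O=C(Nc1ccc(Cl)c(-c2nnc3c(Cl)cccn23)c1)c1ccccc1Cl` differs from compound 1 by hydrogen in place of trifluoromethyl on an aromatic carbon. Going by the values given here, no measured step bears on that change, and the only neighbour, compound 1, stands at a limit rather than at a number. Because compound 1 shows only > 100000 nM, compound 4 is expected to remain at or near that limit, with no step beyond the scatter, so that a number no higher from compound 1 to compound 4 (the limit leaves the size open) is the expected outcome. Compound 4 is therefore estimated at 100000 nM, within a range from 30000 nM to 300000 nM.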

Compound 4, half-maximal inhibitory concentration: > 100000 nM
Compound 4: a limit, no number; the forecaster's own chance of this, stated with the estimate: 70%; the middle value sits exactly at the limit.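

In this assay compound 4 gives > 100000 nM, which is a limit of the assay and not a number, so hydrogen in place of trifluoromethyl on this aromatic carbon does not yield a readable value. The steps to compound 4 from compound 1 and from compound 3 cannot be read. For the compounds shown here, the one readable step, an at least 1.3-fold higher number from compound 2 to compound 4 (0.12 log units; that floor lies within the scatter), concerns the whole group on the carbonyl carbon and says nothing about this position alone, and the series remains largely confined to one limit: the limit of > 100000 nM in this assay, at which 3 of the 4 values shown sit.

Whether trifluoromethyl and hydrogen differ at all at this position stays hidden behind that limit. Also open, going by these compounds, is whether an amine or a carboxylic acid on this aromatic carbon would give a measurable value in this assay.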